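Sulfonyl aryl swap on the piperazine series: benzothiophene to chlorophenyl

This account rests on a few compounds, and the source may have more. Where it says the series, first, only, none or still open, it means among the compounds named here.

Two members of the series have numbers in a functional assay on Chem-1 cells for antagonist activity at C-X-C chemokine receptor type 4 (Homo sapiens), read by calcium flux (on this read-out higher numbers stand for weaker inhibition and lower numbers for stronger inhibition), so far. Compound 1 `NCCCCN(C[C@H]1CN(C(=O)OCc2ccccc2)CCN1)[C@H]1CCCc2cccnc21` carries a benzyl carbamate on the ring nitrogen and gives 18 nM. Compound 2 `NCCCCN(C[C@H]1CN(S(=O)(=O)c2cc3ccccc3s2)CCN1)[C@H]1CCCc2cccnc21` replaces that with a benzothiophene sulfonamide and gives 39 nM, the highest number of the two, beyond the scatter relative to compound 1. Compound 3 `NCCCCN(C[C@H]1CN(S(=O)(=O)c2ccc(Cl)cc2)CCN1)[C@H]1CCCc2cccnc21` keeps the sulfonamide and differs from compound 2 in one place: 4-chlorophenyl in place of 1-benzothiophen-2-yl on a sulfonyl sulfur. Going by the values given here, no measured pair shows a step of this kind, so the size of the move is open; the two aryl sulfonyl groups have no direct comparison here. The change is expected to stay within the scatter, with a step from compound 2 to compound 3 of about a 1.2-fold higher number from compound 2 to compound 3 (0.06 log units; within the scatter) in this assay. Compound 3 is estimated at 45 nM, within a range of 15 nM to 140 nM.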

Compound 3, half-maximal inhibitory concentration: 2 nM
Beside the measured number, compound 3's estimate is 23-fold (1.35 log units) above it; measured number outside the range, below it.
By their numbers in this assay, from the lowest: compound 3; then compound 1; then compound 2.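

In this assay the move to 4-chlorophenyl on the sulfonyl sulfur gives a 20-fold lower number from compound 2 to compound 3 (1.29 log units; beyond the scatter) and shows that this position is highly sensitive to the aryl group it carries. The sulfonamide link does not by itself rank below the benzyl carbamate, as the step of a 9.0-fold lower number from compound 1 to compound 3 (0.95 log units; beyond the scatter) puts compound 3 ahead of compound 1, while compound 2 sits behind it. Nothing measured here accounts for either step.

Going by these compounds, whether the chlorine or the loss of the five-membered ring carries the gain remains open, and phenyl, 4-fluorophenyl or 1-benzothiophen-3-yl on the sulfonyl sulfur would help separate the two. Also open, on these data alone, is whether the 4-chlorophenyl gain persists when the aminobutyl chain gives way to a longer chain ending in the same amine.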